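Furan Replaces Hydroxyphenyl on a Shared Core

A few compounds are considered here, and "the series" means these few. Any claim that something is new, unique, unknown or untested is made for them only; others in the source may bear on it.

Compound 3, `Nc1nc(-c2cccc(O)c2)nc2sc(-c3ccccc3)nc12`, is one of three compounds examined in a functional assay on CHO cells for antagonist activity at adenosine receptor A2b (Homo sapiens), read by cAMP accumulation, with a stated time of 10 min; on this read-out higher numbers stand for weaker inhibition and lower numbers for stronger inhibition. In this assay compound 3 reaches only the limit > 30000 nM. Compound 1, `Nc1nc(-c2cccc(CO)c2)nc2sc(-c3ccccc3)nc12`, likewise reaches only the limit > 30000 nM. Compound 2, `COc1cccc(-c2nc(N)c3nc(-c4ccccc4)sc3n2)c1`, also stops at the limit > 30000 nM. The steps between these three, a step that the two limits leave unreadable from compound 1 to compound 2, a step that the two limits leave unreadable from compound 1 to compound 3 and a step that the two limits leave unreadable from compound 2 to compound 3, cannot be read because the limit of > 30000 nM in this assay, at which 3 of the 3 values shown sit, governs every value shown, so compound 3 stands at that limit together with both of its neighbours, and no ordering among them can be stated.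

Compound 4, `Nc1nc(-c2ccco2)nc2sc(-c3ccccc3)nc12`, differs from compound 3 by furan-2-yl in place of 3-hydroxyphenyl on an aromatic carbon. Among the measured compounds shown here, none of the measured steps touches this exchange; each of them alters only the group on the phenyl ring, and none of them yields a readable size. The expectation for compound 4 therefore rests solely on the fact that every measured compound stays at the limit. On these data alone, the step from compound 3 to compound 4 is expected to be a number no higher from compound 3 to compound 4 (the limit leaves the size open), although its true size is unknown. Compound 4 is estimated at 30000 nM, with a range from 5000 nM to 100000 nM, and the assay is expected most likely to report only a limit again.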

Compound 4, half-maximal inhibitory concentration: > 30000 nM
Compound 4: no number, only a limit; the forecaster's own chance of this, stated with the estimate: 70%; the middle value lies on the limit itself.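

The steps from compound 1, compound 2 and compound 3 to compound 4 cannot be read, because all four compounds stop at one shared limit: the limit of > 30000 nM in this assay, at which 4 of the 4 values shown sit.

The compounds shown leave open how strongly any of them inhibits, and whether furan-2-yl and 3-hydroxyphenyl differ at all in this assay.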